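This account rests on a few compounds, and the source may have more. Where it says the series, first, only, none or still open, it means among the compounds named here.

Measured so far in a physicochemical assay for lipophilicity, read by HPLC; on this read-out higher numbers stand for higher lipophilicity and lower numbers for lower lipophilicity:
compound 1 `O=C(Nc1ccc(F)cc1)c1ccc2cccc(O)c2n1` gives 2.5;
compound 2 `O=C(Nc1ccc(Cl)cc1)c1ccc2cccc(O)c2n1` gives 2.5;
compound 3 `O=C(Nc1cccc(Br)c1)c1ccc2cccc(O)c2n1` gives 2.5.

On these numbers compound 3 stands level with compounds 1 and 2 in this assay. The next compound, compound 4 `O=C(Nc1ccc(Br)cc1)c1ccc2cccc(O)c2n1`, differs from it in one place: 4-bromophenyl in place of 3-bromophenyl on an amide-type nitrogen. For the measured compounds named here, three measured steps bear on this exchange of a halogenated phenyl on the amide-type nitrogen, and each was flat: no change at the digits printed from compound 1 to compound 2 (within the scatter), no change at the digits printed from compound 1 to compound 3 (within the scatter) and no change at the digits printed from compound 2 to compound 3 (within the scatter). Every such swap so far has left this assay unchanged, so compound 4 is expected to show no step beyond the scatter, no change at the digits printed from compound 3 to compound 4 (within the scatter). The estimate for compound 4 is therefore 2.5, with a range from 2.2 to 2.8.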

Compound 4, partition coefficient: 2.5
Compound 4: the middle estimate sits on the measured number at the digits printed; measured number inside the range.
By their numbers in this assay, from the lowest: compounds 1, 2, 3 and 4 (each within the scatter of the next).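

In this assay, for the compounds shown here, 4-bromophenyl in place of 3-bromophenyl on the amide-type nitrogen gives no change at the digits printed from compound 3 to compound 4 (within the scatter) and is the first step here to change the halogen's place while keeping the halogen the same. With 4-substitution held, exchanging the halogen alone reads no change at the digits printed from compound 2 to compound 4 (within the scatter) and no change at the digits printed from compound 1 to compound 4 (within the scatter) as well. Nothing available here accounts for these flat steps. All the compounds shown carry a halogen on this phenyl, so whether a methoxy, an amine or a carboxylic acid in its place would move this assay remains open.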